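This account rests on a few compounds, and the source may have more. Where it says the series, first, only, none or still open, it means among the compounds named here.

Compound 1, `Cn1cncc1C(OCc1ccc(C#N)cc1-c1cccc(Cl)c1)c1ccc(C#N)nc1`: 8620 nM
Compound 2, `Cn1cncc1C(OCc1nc(N2CCC(C(N)=O)CC2)c(C#N)cc1-c1cccc(Cl)c1)c1ccc(C#N)cc1`: 2100 nM

In an assay on isolated protein (Bos taurus) for inhibition of geranylgeranyl transferase type-1 subunit beta (Homo sapiens) (on this read-out higher numbers stand for weaker inhibition and lower numbers for stronger inhibition), compound 1 gives 8620 nM, the highest of the two numbers, so it is the weaker of the pair. Compound 2 gives 2100 nM, a gap that lies beyond the scatter of the measurement. Compound 3, `Cn1cncc1C(OCc1ccc(C#N)cc1-c1cccc(OC(F)(F)F)c1)c1ccc(C#N)nc1`, is not yet measured; it differs from compound 1 in one place: trifluoromethoxy in place of chloro on an aromatic carbon. Among the measured compounds shown here, no measured pair shows this change, so the expected step from compound 1 to compound 3 is put at a 1.0-fold higher number from compound 1 to compound 3 (0.02 log units; within the scatter), within the scatter and in no clear direction. Compound 3 is expected to give about 9000 nM, between 3000 nM and 27000 nM.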

Compound 3, half-maximal inhibitory concentration: 990 nM
Beside the measured number, compound 3's estimate is 9.1-fold (0.96 log units) above it; measured number outside the range, below it.
By their numbers in this assay, from the lowest: compound 3; then compound 2; then compound 1.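

Going from 3-chlorophenyl to 3-(trifluoromethoxy)phenyl gives an 8.7-fold lower number from compound 1 to compound 3 (0.94 log units; beyond the scatter) in this assay, so this position on the aromatic ring is sensitive to what is placed on it. The earlier compounds shown here carried only chloro here, and this step shows that a group with more heavy atoms and a hydrogen-bond acceptor can sit there with stronger inhibition. No measured evidence on hand accounts for the size of this step.

As far as these compounds go, whether the same change would act alike on the core of compound 2 remains open. So does the outcome with a methoxy group or an amine at this place.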